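The source may hold more compounds than are shown below. What is called first, only, known or untested is meant among the compounds shown, and "the series" means these compounds.

Compound 2 `O=C(Nc1ccc(F)cc1)c1ccc(CNc2nc(NC3CC3)nc3ccccc23)cc1` is the reference point here. In a functional assay on SW480 cells (Homo sapiens) for inhibition, read by luminescence and resazurin assay, with a stated time of 3 days (on this read-out lower numbers stand for stronger inhibition and higher numbers for weaker inhibition), compound 2 gives 2600 nM; compound 1 `O=S(=O)(Nc1ccc(CNc2nc(NC3CC3)nc3ccccc23)cc1)c1ccc(F)cc1` gives 4100 nM, a gap that stays within the scatter, while compound 3 `CN(C)c1nc(NCc2ccc(C(=O)N3CCC(C(=O)NCc4ccc(F)cc4)CC3)cc2)c2ccccc2n1` gives 5500 nM, a gap that lies beyond it. For the measured compounds named here, the only measured step, a 1.6-fold lower number from compound 1 to compound 2 (0.20 log units; within the scatter), concerns a different part of the molecule and does not touch the amine in question. Compound 4 `C=CCNc1nc(NCc2ccc(C(=O)Nc3ccc(F)cc3)cc2)c2ccccc2n1` differs from compound 2 by allyl in place of cyclopropyl on a nitrogen on an aromatic ring. Going by the values given here, no measured pair speaks to this exchange, so the author expects a step in this assay of no clear direction and no size beyond the scatter, written as a 1.1-fold higher number from compound 2 to compound 4 (0.03 log units; within the scatter). For compound 4 the expected value is 2800 nM, within a range from 1300 nM to 6000 nM.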

Compound 4, half-maximal inhibitory concentration: 11000 nM
For compound 4 the middle estimate is 3.9-fold (0.59 log units) below the measured one; measured number outside the range, above it.
By their numbers in this assay, from the lowest: compounds 2, 1, 3 and 4 (each within the scatter of the next, the first and the last beyond it).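

In this assay, the change from cyclopropylamino to allylamino is not neutral (a 4.2-fold higher number from compound 2 to compound 4 (0.63 log units; beyond the scatter)), even though both groups hold 3 carbon atoms. For the compounds shown here, the earlier step lay elsewhere in the molecule, so this is the first sign that inhibition responds to the group on this nitrogen, with the ring form favoured over allyl in this single pair. Nothing measured here explains the step. Going by these compounds, it remains open whether the weaker inhibition follows from losing the ring or from gaining the double bond. A saturated propyl group or a larger cyclobutyl ring on the same nitrogen would bear on this.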